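Swapping the thiazole amide for a benzodioxin amide

A few compounds are considered here, and "the series" means these few. Any claim that something is new, unique, unknown or untested is made for them only; others in the source may bear on it.

Compound 1 `O=C(NC1CCCCC1)NS(=O)(=O)N1CCC(CCNC(=O)c2cscn2)CC1`: 23%
Compound 2 `CCCNC(=O)NS(=O)(=O)N1CCC(CCNC(=O)c2cscn2)CC1`: 10%
Compound 3 `O=C(NC[C@@H]1C[C@@H]2C=C[C@@H]1C2)NS(=O)(=O)N1CCC(CCNC(=O)c2nc3ccccc3s2)CC1`: 24%

In a functional assay on the whole organism (blood) with Rattus norvegicus as the target, with stated times of 24 h and 1 h, at a dose of 5 mg/kg by the intraperitoneal route (on this read-out lower numbers stand for a weaker effect and higher numbers for a stronger effect at the one dose given), compound 1 gives 23%. Of the three numbers it is the second highest: compound 3 gives 24%, which lies within the scatter of compound 1, while compound 2 gives 10%, the furthest of the three. For the measured compounds named here, that last gap is the only step between neighbours that differ in one place, a number 13 percentage points lower from compound 1 to compound 2 (beyond the scatter), and it concerns the nitrogen on the urea side of the shared core, not the amide end.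

Compound 4 `O=C(NC1CCCCC1)NS(=O)(=O)N1CCC(CCNC(=O)c2cccc3c2OCCO3)CC1` changes the amide end instead: 2,3-dihydro-1,4-benzodioxin-5-yl in place of 1,3-thiazol-4-yl on a carbonyl carbon. Going by the values given here, no measured step touches this position, since compound 3 differs from compound 1 in two places at once, so the data give no direction for the change. With nothing to lean on, the expectation for compound 4 is a step of about a number 3 percentage points lower from compound 1 to compound 4 (within the scatter), that is, none beyond the scatter, but with a broad range. Compound 4 is therefore estimated at 20%, expected between 5% and 40% in this assay.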

Compound 4, a percentage reported as activity, at one dose (the size of the read-out at that dose, not a potency): 34%
For compound 4 the middle estimate is 14 percentage points below the measured one, within the range that was stated.
By their numbers in this assay, from the lowest: compound 2; then compounds 1, 3 and 4 (each within the scatter of the next, the first and the last beyond it).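

In this assay, for the compounds shown here, the step 2,3-dihydro-1,4-benzodioxin-5-yl in place of 1,3-thiazol-4-yl on a carbonyl carbon gives a number 11 percentage points higher from compound 1 to compound 4 (beyond the scatter), the first reading at this position from a change made in one place only. It shows that the amide end of the shared core is not indifferent to the group it carries, as the nitrogen on the urea side had already proved to be for its own substituent, and that, with cyclohexyl held fixed, replacing a five-membered aromatic ring with a larger two-ring group that has the same hydrogen-bond donor and acceptor counts is compatible with a stronger effect at the one dose given. Nothing in the information available accounts for the step.

The compounds shown leave open whether a plain phenyl or a 2,3-dimethoxyphenyl group on the same carbonyl carbon would match compound 4, so the share of the six-membered non-aromatic ring in this step remains unknown. They also leave open whether the same exchange would give a step of similar size with propyl in place of cyclohexyl, as in compound 2.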